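This account rests on a few compounds, and the source may have more. Where it says the series, first, only, none or still open, it means among the compounds named here.

Measured in a functional assay on Raji cells (Homo sapiens) for antiproliferative activity, read by MTT assay, with a stated time of 72 h; on this read-out higher numbers stand for weaker inhibition and lower numbers for stronger inhibition:
- compound 1 `CN(Cc1nc(C2CCN(Cc3ccccc3F)CC2)no1)c1ncc(C(=O)NO)cn1`: 98.6 nM
- compound 2 `CN(Cc1nc(C2CCN(Cc3ccccc3Cl)CC2)no1)c1ncc(C(=O)NO)cn1`: 48.3 nM
- compound 3 `CN(Cc1nc(C2CCN(Cc3ccc(F)cc3F)CC2)no1)c1ncc(C(=O)NO)cn1`: 34.3 nM

Compound 3, at 34.3 nM, belongs to the low end of this small set. The series shows a 1.4-fold lower number from compound 2 to compound 3 (0.15 log units; within the scatter), and also a 2.9-fold lower number from compound 1 to compound 3 (0.46 log units; beyond the scatter).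

Compound 4 `CN(Cc1nc(C2CCN(Cc3ccc(F)cc3Cl)CC2)no1)c1ncc(C(=O)NO)cn1` has not yet been measured in this assay. It replaces the 2,4-difluorobenzyl group of compound 3 with 2-chloro-4-fluorobenzyl: chloro in place of fluoro on an aromatic carbon. Among the measured compounds shown here, the only measured step of the same kind, chloro in place of fluoro on an aromatic carbon, is a 2.0-fold lower number from compound 1 to compound 2 (0.31 log units; beyond the scatter). That single example is modest, and it comes from compounds without the fluoro group that compound 4 retains. The data do not show whether it carries over to this setting. A step in the same direction is therefore expected in this assay, but smaller, and it may not clear the scatter.

The estimated step is a 1.7-fold lower number from compound 3 to compound 4 (0.23 log units; within the scatter). For compound 4 the estimated value is 20 nM, with an expected range of 9 nM to 45 nM.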

Compound 4, half-maximal inhibitory concentration: 116 nM
Compound 4: middle estimate off by 5.8-fold (0.76 log units), on the low side; the measured number lies above the stated range.
By their numbers in this assay, from the lowest: compounds 3 and 2 (each within the scatter of the next); then compounds 1 and 4 (each within the scatter of the next).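

Chloro in place of fluoro, ortho to a large group, has no fixed direction here. With the second fluoro group in place, it gives a 3.4-fold higher number from compound 3 to compound 4 (0.53 log units; beyond the scatter), the reverse of the step on the core of compound 1: the same change on two cores in this assay, a 2.0-fold lower number (0.31 log units; beyond the scatter) from compound 1 to compound 2 and a 3.4-fold higher number (0.53 log units; beyond the scatter) from compound 3 to compound 4, 6.9-fold (0.84 log units) apart, beyond the scatter of two such steps. Fluoro in place of hydrogen reverses in the same way, giving a 2.4-fold higher number from compound 2 to compound 4 (0.38 log units; beyond the scatter) on the 2-chlorophenyl group, so the two changes do not add: the same change on two cores in this assay, a 2.9-fold lower number (0.46 log units; beyond the scatter) from compound 1 to compound 3 and a 2.4-fold higher number (0.38 log units; beyond the scatter) from compound 2 to compound 4, 6.9-fold (0.84 log units) apart, beyond the scatter of two such steps. Among the compounds shown here, with both present, the 2-chloro-4-fluorobenzyl group gives a 1.2-fold higher number from compound 1 to compound 4 (0.07 log units; within the scatter), leaving compound 4 within the scatter of the single fluoro compound.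

The compounds shown do not tell why the two positions depend on each other. They also leave open whether a methoxy or methyl group in place of the retained fluoro would show the same dependence, and how a 2,4-dichlorobenzyl group would behave.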